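Sulfonyl to sulfonimidoyl at the distal sulfur of compound 1

This account rests on a few compounds, and the source may have more. Where it says the series, first, only, none or still open, it means among the compounds named here.

Compound 1 `CCCN(CCC)S(=O)(=O)c1ccc(S(=O)(=O)N2CCC[C@@H](C(=O)OCC)C2)cc1` gives the lowest number of the three measured in a functional assay on MIA PaCa-2 cells (Homo sapiens) for inhibition, read by MTT assay, with a stated time of 3 days (on this read-out lower numbers stand for stronger inhibition and higher numbers for weaker inhibition), at 600 nM. Among the compounds with values here, compound 2 `CCN(CC)S(=O)(=O)c1ccc(S(=O)(=O)N2CCC[C@@H](C(=O)NC)C2)cc1` gives 2000 nM, and compound 3 `CCN(CC)S(=O)(=O)c1ccc(S(=O)(=O)N2CCC[C@@H](C(=O)NC3CN(C(=O)NC(C)(C)C)C3)C2)cc1` gives 1400 nM; the only single-point step, a 1.4-fold lower number from compound 2 to compound 3 (0.15 log units; within the scatter), sits on the amide side and does not touch the change considered here. Compound 4 `CCOC(=O)[C@@H]1CCCN(S(=O)(=O)c2ccc(S(=N)(=O)N(CC)CC)cc2)C1` differs from compound 1 by a group of 8 heavy atoms (4 carbon, 2 nitrogen, 1 oxygen, 1 sulfur; no ring) in place of a group of 10 heavy atoms (6 carbon, 1 nitrogen, 2 oxygen, 1 sulfur; no ring), on an aromatic carbon. Within the data shown here, no measured pair isolates this change; compound 1 and compound 2 differ at the same sulfamoyl as well as at the ester, so their values give no clean guide. Among the measured compounds shown here, with no direct precedent, a modest loss is expected, a 2.0-fold higher number from compound 1 to compound 4 (0.30 log units; within the scatter), and compound 4 is estimated at 1200 nM, within 400 nM to 4000 nM.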

Compound 4, half-maximal inhibitory concentration: 900 nM
Beside the measured number, compound 4's estimate is 1.3-fold (0.12 log units) above it; low and high end bracket the measured number.
By their numbers in this assay, from the lowest: compounds 1, 4, 3 and 2 (each within the scatter of the next, the first and the last beyond it).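

In this assay, placing the sulfonimidoyl group on this aromatic carbon in place of dipropylsulfamoyl gives a 1.5-fold higher number from compound 1 to compound 4 (0.18 log units; within the scatter), so this change at the distal sulfur, with the ethyl ester held constant, brings no shift beyond the scatter. No measured evidence bears on the reason for this result.

The step combines two edits, shorter chains on the sulfamoyl-derived nitrogen and a sulfonyl oxygen exchanged for nitrogen, so neither can be read alone. On these data alone, a dipropyl sulfonimidoyl group or a piperidine on the sulfur would separate them, and the effect on a methyl amide series remains open.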